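Chloro for Trifluoromethyl, Repeated on a Second Core

The source may report more compounds than this note shows. Statements on the series, on what has been measured and on what is new or still open speak of the compounds shown alone.

Measured in an assay for inhibition of apolipoprotein B-100 (Homo sapiens), tested at 100 nM; on this read-out lower numbers stand for stronger inhibition and higher numbers for weaker inhibition:
compound 1 `COC(=O)NCC1Cc2ccc(NC(=O)c3cccc(C)c3-c3ccc(C(F)(F)F)cc3)cc2C1` gives 4.1 nM
compound 2 `COC(=O)NCC1Cc2ccc(NC(=O)c3cccc(C)c3-c3ccc(Cl)cc3)cc2C1` gives 8.7 nM
compound 3 `COC(=O)NC1CCc2ccc(NC(=O)c3cccc(C)c3-c3ccc(C(F)(F)F)cc3)cc2CC1` gives 1.6 nM

Compound 1 and compound 2 share a core and differ only by chloro in place of trifluoromethyl on an aromatic carbon, a change that produced a 2.1-fold higher number from compound 1 to compound 2 (0.33 log units; beyond the scatter). Compound 3 is built on a different core; the difference between the two cores is not broken down here, but compound 3 shows the lowest number of the three. Compound 4 `COC(=O)NC1CCc2ccc(NC(=O)c3cccc(C)c3-c3ccc(Cl)cc3)cc2CC1` carries that same core of compound 3 and differs from it by chloro in place of trifluoromethyl on an aromatic carbon, the same change made from compound 1 to compound 2. Because compound 1 and compound 2 showed a 2.1-fold higher number from compound 1 to compound 2 (0.33 log units; beyond the scatter), the step is expected to be of similar size, a 2.1-fold higher number from compound 3 to compound 4 (0.33 log units; beyond the scatter). Compound 4 is therefore estimated at 3.4 nM, with a likely range from 1.8 nM to 7 nM.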

Compound 4, half-maximal inhibitory concentration: 2 nM
Estimate against measurement, compound 4: 1.7-fold (0.23 log units) above; the range from low to high includes it.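

In this assay, chloro in place of trifluoromethyl gave a 1.3-fold higher number from compound 3 to compound 4 (0.10 log units; within the scatter), so on the core of compound 3 the two groups cannot be told apart. The step does not differ measurably between the two cores: the same change on two cores in this assay, a 2.1-fold higher number (0.33 log units; beyond the scatter) from compound 1 to compound 2 and a 1.3-fold higher number (0.10 log units; within the scatter) from compound 3 to compound 4, 1.7-fold (0.23 log units) apart, within the scatter of two such steps. Within the data shown here, these two pairs show that the change carried over within the limits of the measurement, but they do not show that it would carry to a further core, and they do not explain why only the step on the core of compound 1 lies beyond the scatter.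

The compounds shown leave open how fluoro, methoxy, nitrile or an amine would read in the same place on the ring. They also leave open how chloro in place of trifluoromethyl would read on a third core.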